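A few compounds are considered here, and "the series" means these few. Any claim that something is new, unique, unknown or untested is made for them only; others in the source may bear on it.

Of the compounds shown here, two have been measured in an assay on isolated protein for binding affinity to C-X-C chemokine receptor type 1 (Homo sapiens); on this read-out lower numbers stand for stronger inhibition and higher numbers for weaker inhibition. Compound 1, with the structure `CC[C@@H](Nc1n[s+]([O-])nc1Nc1cccc(C(=O)N(C)C)c1O)c1cc(C(C)C)co1`, gives 61 nM in this assay. Compound 2, with the structure `Cc1ccc([C@H](NC2=NS(=O)(=O)N=C2Nc2cccc(C(=O)N(C)C)c2O)C2(C)CC2)o1`, gives 1100 nM in this assay. Of the two numbers, compound 2 stands at the higher one, and the gap to compound 1 lies beyond the usual scatter of repeated measurements. These two compounds differ in several places at once, so their values alone do not show which part of the structure is behind the gap.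

Compound 3, with the structure `CC[C@@H](NC1=NS(=O)(=O)N=C1Nc1cccc(C(=O)N(C)C)c1O)c1ccc(C)o1`, has not yet been measured. It keeps the core of compound 2 and differs from it in a single place: ethyl in place of 1-methylcyclopropyl on a saturated chain carbon bound to an amine nitrogen and an aromatic carbon. The group that leaves carries a small ring; the group that enters is a short chain, and compound 1, which also carries an ethyl at the matching position, shows the lower number of the two values known here.

Among the measured compounds shown here, with no measured step for exactly this exchange, the expectation rests on that comparison: the step of a 3.7-fold lower number from compound 2 to compound 3 (0.56 log units; beyond the scatter) is expected to bring the number down by an amount beyond the scatter. Compound 3 is therefore estimated at 300 nM in this assay, with a range from 60 nM to 1500 nM.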

Compound 3, inhibition constant: 5950 nM
Beside the measured number, compound 3's estimate is 20-fold (1.30 log units) below it, outside the stated range (above it).
By their numbers in this assay, from the lowest: compound 1; then compound 2; then compound 3.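

In this assay, putting ethyl in place of 1-methylcyclopropyl on a saturated chain carbon bound to an amine nitrogen and an aromatic carbon gives a 5.4-fold higher number from compound 2 to compound 3 (0.73 log units; beyond the scatter). Among the compounds shown here, this is the first exchange here made in a single place, and it shows that this position matters: with everything else held the same, the short chain without a ring goes with weaker inhibition, so ethyl does not bring a low number on its own, and the low number of compound 1 cannot be credited to its ethyl. Nothing measured here explains why the exchange acts this way.

As far as these compounds go, what stays open is whether the small ring or simply the larger group counts, since a single exchange cannot separate the two, and a plain cyclopropyl, an isopropyl or a longer chain such as butyl at this carbon would be needed to tell them apart. From the compounds shown here alone, it is also open whether the same exchange would give a step of similar size on the core of compound 1, which differs from compound 3 in more than one place.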